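The compounds below may be only part of what the source reports. "The series", "measured", "known", "first", "only" and "open" are said of these compounds alone.

Going by the values given here, in a functional assay on HT-29 cells (Homo sapiens) for cytotoxicity, read by sulforhodamine B assay (a lower number here means a stronger inhibitor, a higher number a weaker inhibitor), compound 1 `C=C1[C@@H](OC(C)=O)C[C@@H]2[C@](C)(CO[Si](C)(C)C(C)(C)C)[C@H](OC(C)=O)CC[C@@]2(C)[C@@H]1C[C@@H](Nc1ccc(Br)cc1)C1=CCOC1=O` gives 4590 nM, the lowest of the three numbers measured so far. Compound 2 `C=C1CC[C@@H]2[C@](C)(CO[Si](C)(C)C(C)(C)C)[C@H](OC(C)=O)CC[C@@]2(C)[C@@H]1C/C=C1/C(=O)OC[C@H]1OC(C)=O` gives 4690 nM, a value that sits within the scatter of compound 1, so the two cannot be told apart. Compound 3 `C=C1[C@@H](OC(C)=O)C[C@@H]2[C@](C)(COC=O)[C@H](OC(C)=O)CC[C@@]2(C)[C@@H]1C[C@@H](Nc1ccc(OC)cc1)C1=CCOC1=O` gives 25400 nM, a weaker result that lies beyond the scatter from compound 1. Compound 4 `C=C1[C@@H](OC(C)=O)C[C@@H]2[C@](C)(CO[Si](C)(C)C(C)(C)C)[C@H](OC(C)=O)CC[C@@]2(C)[C@@H]1C[C@@H](Nc1cccc2ccccc12)C1=CCOC1=O` has not yet been measured. It differs from compound 1 in one place: naphthalen-1-yl in place of 4-bromophenyl on an amine nitrogen. Among the compounds with values here, no measured pair in this set shows what such a change does, so there is no direct precedent to lean on, and the rest of the molecule stays as it is in compound 1. The expected step is a 1.1-fold higher number from compound 1 to compound 4 (0.04 log units; within the scatter), which amounts to no change beyond the usual scatter. On that basis compound 4 is estimated at 5000 nM, with a plausible range from 1500 nM to 16000 nM.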

Compound 4, half-maximal inhibitory concentration: 15000 nM
For compound 4 the middle estimate is 3.0-fold (0.48 log units) below the measured one; low and high end bracket the measured number.
By their numbers in this assay, from the lowest: compounds 1 and 2 (each within the scatter of the next); then compounds 4 and 3 (each within the scatter of the next).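

In this assay, the group on the amine nitrogen proves able to move the number: putting naphthalen-1-yl in place of 4-bromophenyl gives a 3.3-fold higher number from compound 1 to compound 4 (0.51 log units; beyond the scatter), a modest weakening that lies beyond the scatter. Going by these compounds alone, this is the first comparison in the set that changes only one place, and it shows that this position does not accept every aromatic group equally. Within the data shown here, the single pair cannot separate the loss of the bromine from the gain of a second aromatic ring, and nothing measured here explains the shift.

On these data alone, it remains open whether a plain phenyl or a 4-chlorophenyl on the same nitrogen would stay close to compound 1 or fall toward compound 4. A non-aromatic cyclohexyl there would test whether this position needs an aromatic ring at all.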